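This account rests on a few compounds, and the source may have more. Where it says the series, first, only, none or still open, it means among the compounds named here.

In a functional assay on MCF7 cells (Homo sapiens) for cytotoxicity, read by MTT assay, with a stated time of 72 h (on this read-out lower numbers stand for stronger inhibition and higher numbers for weaker inhibition), three compounds built on one shared core have been measured. Compound 1 `COc1ccc(/C=C/C(=O)Nc2cc3c(Nc4ccc(F)c(Cl)c4)ncnc3cc2OC)c(OC)c1` gives 36600 nM and compound 3 `COc1cc(/C=C/C(=O)Nc2cc3c(Nc4ccc(F)c(Cl)c4)ncnc3cc2OC)cc(OC)c1` gives 38500 nM. Compound 2 `O=C(/C=C/c1cccc(Cl)c1Cl)Nc1cc2c(Nc3ccc(F)c(Cl)c3)ncnc2cc1O[C@H]1CCOC1` gives 30100 nM, the lowest of the three numbers shown, although its gaps to compound 1 and to compound 3 both lie within the scatter. Compound 4 `N#Cc1ccc(/C=C/C(=O)Nc2cc3c(Nc4ccc(F)c(Cl)c4)ncnc3cc2O[C@H]2CCOC2)cc1` differs from compound 2 in one place: 4-cyanophenyl in place of 2,3-dichlorophenyl on a double-bonded chain carbon bound to a double-bonded chain carbon. Among the measured compounds shown here, the only measured step at this place is a 1.1-fold higher number from compound 1 to compound 3 (0.02 log units; within the scatter), an exchange of one substituted phenyl for another that left the number essentially unchanged. On that basis the analyst expects the step to be a 1.1-fold higher number from compound 2 to compound 4 (0.04 log units; within the scatter), nothing beyond the scatter in this assay. For compound 4 the estimate is 33000 nM, with a range from 15000 nM to 75000 nM.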

Compound 4, half-maximal inhibitory concentration: 9830 nM
Compound 4: the middle estimate sits 3.4-fold (0.53 log units) above what was measured; the measured number lies below the stated range.
By their numbers in this assay, from the lowest: compound 4; then compounds 2, 1 and 3 (each within the scatter of the next).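

In this assay the change on a double-bonded chain carbon bound to a double-bonded chain carbon gives a 3.1-fold lower number from compound 2 to compound 4 (0.49 log units; beyond the scatter) and thus lies beyond the scatter, unlike a 1.1-fold higher number from compound 1 to compound 3 (0.02 log units; within the scatter) on the methoxy-bearing compounds. Exchanging one substituted phenyl for another at this place can therefore move the number, although the step is modest. No evidence is available on what lies behind this step. As far as these compounds go, whether it follows from the nitrile or from the absence of the two chlorines stays open, as does how a 4-aminophenyl or 4-carboxyphenyl group would read at this place.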